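A few compounds are considered here, and "the series" means these few. Any claim that something is new, unique, unknown or untested is made for them only; others in the source may bear on it.

Measured so far:
- compound 1, `O=c1c(CCO)c(-c2ccccc2Cl)c2cc(Cl)ccc2n1-c1c(F)cccc1F`: > 2300000 nM in an ADME assay on HepG2 2.2.15 cells (Homo sapiens) for cytotoxicity; a higher number here means that more compound is tolerated, a lower number that less compound is tolerated
- compound 2, `CC(=O)N1CCC(C(=O)OCCc2c(-c3ccccc3Cl)c3cc(Cl)ccc3[nH]c2=O)CC1`: 82000 nM

Compound 1 carries a hydroxyethyl chain on the shared core and is reported in this assay only as a limit of > 2300000 nM, not as a number. Compound 2 attaches the same chain through an ester to an acetylated piperidine ring and gives 82000 nM in this assay. Among the measured compounds shown here, this value is the only number in the set; the other entry is a limit, (the limit of > 2300000 nM in this assay, at which 1 of the 2 values shown sits), so compound 2 has no measured neighbour against which a step could be sized.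

Compound 3, `C/C=C/C=C/C(=O)OCCc1c(-c2ccccc2Cl)c2cc(Cl)ccc2[nH]c1=O`, is the next member to be tested in this assay. It differs from compound 2 at the ester: penta-1,3-dien-1-yl in place of 1-acetylpiperidin-4-yl on a carbonyl carbon. The ring with its acetyl group leaves and an open chain of five carbons with two double bonds enters on the carbonyl carbon whose other neighbour is the ester oxygen.

For the measured compounds named here, no measured step covers such a change. With nothing else in the set to lean on, the step of a 1.6-fold lower number from compound 2 to compound 3 (0.21 log units; within the scatter) is expected to stay close to the scatter, if anything towards less tolerance. For compound 3 the half-maximal cytotoxic concentration in this assay is estimated at 50000 nM, between 12000 nM and 200000 nM.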

Compound 3, half-maximal cytotoxic concentration: 440000 nM
For compound 3 the middle estimate is 8.8-fold (0.94 log units) below the measured one; measured number above the stated range.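

In this assay, among the compounds shown here, replacing 1-acetylpiperidin-4-yl with penta-1,3-dien-1-yl on the carbonyl carbon gives a 5.4-fold higher number from compound 2 to compound 3 (0.73 log units; beyond the scatter) and provides the first step that can be sized. The group on this ester carbonyl therefore matters for the half-maximal cytotoxic concentration in this pair, with more compound tolerated with the open chain carrying two double bonds than with the acetylated ring. No measurement shown bears on the reason for this difference.

A single pair cannot separate the contributions of the ring, the acetyl group and the two double bonds; a saturated pentyl chain or a piperidine ring without the acetyl group on the same ester would begin to divide the step among them. Compound 1 is reported only as the limit > 2300000 nM and differs from the two esters in more than one place, so steps involving it cannot be read.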